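This account rests on a few compounds, and the source may have more. Where it says the series, first, only, none or still open, it means among the compounds named here.

Compounds measured so far:

Compound 1, `Nc1cc(N)c2nc(-c3ccccc3)c(Oc3ccc(Cl)c(Cl)c3)nc2c1` — 39800 nM in a functional assay on KM12 cells (Homo sapiens) for inhibition, read by sulforhodamine B assay, with a stated time of 48 h; a higher number here means a weaker inhibitor of growth, a lower number a stronger inhibitor of growth
Compound 2, `Nc1cc(N)c2nc(-c3ccccc3)c(NCc3ccc(Cl)c(Cl)c3)nc2c1` — 21400 nM
Compound 3, `CCOC(=O)[C@H](CCC(=O)O)NC(=O)c1ccc(Oc2nc3cc(N)cc(N)c3nc2-c2ccccc2)cc1` — < 100000 nM

Of these three results in this assay, compound 3 gives only a limit of the assay, (the limit of < 100000 nM in this assay, at which 1 of the 3 values shown sits), and not a number. The two numbers belong to compound 1 and compound 2. Compound 2 has the lower of the two, but its gap to compound 1 lies within the scatter of the method, so the two compounds cannot be told apart on these figures. Going by the values given here, no step between two measured compounds that differ in a single place has been recorded, so the study so far offers no guide to how large a change one substituent swap can bring in this assay.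

The compound now in question is compound 4, `COc1ccc(CNc2nc3cc(N)cc(N)c3nc2-c2ccccc2)cc1`. Compared with compound 2 it carries 4-methoxyphenyl in place of 3,4-dichlorophenyl on a saturated chain carbon bound to a nitrogen on an aromatic ring.

Among the compounds with values here, with no measured step to lean on, the account expects the change from compound 2 to compound 4 in this assay to be small, roughly a 1.5-fold higher number from compound 2 to compound 4 (0.17 log units; within the scatter), in the direction of a weaker inhibitor of growth. Compound 4 is thus estimated at 32000 nM, with a plausible range from 10000 nM to 95000 nM.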

Compound 4, concentration for total growth inhibition: 26300 nM
The estimate for compound 4 lay 1.2-fold (0.09 log units) above the measured number, within the range that was stated.
By their numbers in this assay, from the lowest: compounds 2, 4 and 1 (each within the scatter of the next).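

In this assay, going by these compounds alone, the first step between compounds that differ in a single place now reads a 1.2-fold higher number from compound 2 to compound 4 (0.09 log units; within the scatter) for 4-methoxyphenyl in place of 3,4-dichlorophenyl on a saturated chain carbon bound to a nitrogen on an aromatic ring, so compound 2 and compound 4 cannot be told apart. The two groups match in heavy atoms and each holds one six-membered aromatic ring of carbon only, while the entering group carries a hydrogen-bond acceptor that the leaving group lacks, and this exchange of chlorine for oxygen-bearing substitution gives a step that stays within the scatter. Nothing measured among the compounds shown bears on why this exchange gives so small a step.

The compounds shown leave open whether an amine or a carboxylic acid in place of the 4-methoxyphenyl, or a longer chain in place of the single saturated carbon, would give a step beyond the scatter. They also leave open how any change elsewhere on the shared core would read, as this one step covers a single place.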